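Removing a Methyl from an Amide in a Pyrazole Series

This account rests on a few compounds, and the source may have more. Where it says the series, first, only, none or still open, it means among the compounds named here.

Measured compounds:
- compound 1, `O=C(Nc1ccc(Br)cc1CN1C(=O)c2ccccc2C1=O)c1ccccn1`, 740 nM
- compound 2, `Cc1ccc(C(=O)Nc2cc(-c3ccccc3)nn2-c2ccccc2)cc1`, 30 nM

Of the compounds shown here, two have been measured in an assay on CHO cells with metabotropic glutamate receptor 5 (Homo sapiens) as the target; a higher number here means that more compound is needed for the effect, a lower number that less compound is needed. Compound 1 gives 740 nM. Compound 2 gives 30 nM, the lowest of the two numbers; its nearest neighbour is compound 1, whose number is higher by a margin beyond the scatter. The two compounds share no single-point difference, so nothing can be read from them about the effect of one change alone.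

Compound 3, `O=C(Nc1cc(-c2ccccc2)nn1-c1ccccc1)c1ccccc1`, is the next compound, not yet measured. It differs from compound 2 in one place: hydrogen in place of methyl on an aromatic carbon. In words, hydrogen stands in place of methyl on an aromatic carbon, so that the (4-methylphenyl)carbonyl becomes a benzoyl.

Among the compounds with values here, no measured pair shows this change, so the expectation rests on the general experience that loss of a single methyl from such a position seldom moves the number far. The step from compound 2 to compound 3 is expected to be small and upward, a 2.0-fold higher number from compound 2 to compound 3 (0.30 log units; within the scatter), close to the scatter. Compound 3 is therefore estimated at 60 nM, within a range from 20 nM to 200 nM.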

Compound 3, half-maximal effective concentration: 40 nM
For compound 3 the middle estimate is 1.5-fold (0.18 log units) above the measured one; measured number inside the range.
By their numbers in this assay, from the lowest: compounds 2 and 3 (each within the scatter of the next); then compound 1.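

With compound 3 the series gains its first reading of one change alone in this assay and the step is a 1.3-fold higher number from compound 2 to compound 3 (0.12 log units; within the scatter) for hydrogen in place of methyl on an aromatic carbon. At this place, on the ring of the (4-methylphenyl)carbonyl group, the methyl can therefore be taken away without a change that the assay can separate from the scatter, and a plain benzoyl serves as well as the (4-methylphenyl)carbonyl in this one comparison. Nothing at hand gives a reason for this outcome, and it rests on a single pair.

The compounds shown leave open whether this place accepts anything other than methyl and hydrogen, such as an ethyl or longer chain, a methoxy group, chlorine, an amine or a carboxylic acid, any of which might move the number well beyond the scatter. They also leave open whether removing a methyl would have so small an effect on another part of the shared core, or in a compound of a different kind such as compound 1.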